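A few compounds are considered here, and "the series" means these few. Any claim that something is new, unique, unknown or untested is made for them only; others in the source may bear on it.

Of the compounds shown here, three built on one shared core have been tested in a functional assay on HeLa cells (Homo sapiens) for inhibition, read by MTT assay, with a stated time of 72 h; on this read-out higher numbers stand for weaker inhibition and lower numbers for stronger inhibition. Compound 2 `CN(C(=O)NC(=O)c1ccc(C(F)(F)F)cc1)c1nc(C(F)(F)F)c(C(=O)N/N=C/c2cccc(C(F)(F)F)c2)s1` gives 6.2 ug/mL. Compound 3 `CN(C(=O)NC(=O)c1ccc(C(F)(F)F)cc1)c1nc(C(F)(F)F)c(C(=O)N/N=C/c2cc(C(F)(F)F)cc(C(F)(F)F)c2)s1` gives 5.78 ug/mL; its core differs from that of compound 2 by hydrogen in place of trifluoromethyl on an aromatic carbon, and the two values lie within the usual scatter of each other. Compound 1 `CN(C(=O)NC(=O)c1ccc(F)c(F)c1)c1nc(C(F)(F)F)c(C(=O)N/N=C/c2cc(C(F)(F)F)cc(C(F)(F)F)c2)s1` gives 4.45 ug/mL. Compound 1 comes from compound 3 through the change (3,4-difluorophenyl in place of 4-(trifluoromethyl)phenyl on a carbonyl carbon), and that change made a 1.3-fold lower number from compound 3 to compound 1 (0.11 log units; within the scatter), a step too small to be told apart from repeat measurement.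

Compound 4 `CN(C(=O)NC(=O)c1ccc(F)c(F)c1)c1nc(C(F)(F)F)c(C(=O)N/N=C/c2cccc(C(F)(F)F)c2)s1` has not yet been measured. It comes from compound 2 through (3,4-difluorophenyl in place of 4-(trifluoromethyl)phenyl on a carbonyl carbon), the same change made at the same place, only on the core in which compound 2 carries a hydrogen where compound 3 carries a trifluoromethyl group. Because the earlier step of a 1.3-fold lower number from compound 3 to compound 1 (0.11 log units; within the scatter) stayed within the scatter, a step of similar size is expected here, a 1.3-fold lower number from compound 2 to compound 4 (0.11 log units; within the scatter). Starting from compound 2 and its value 6.2 ug/mL, compound 4 is expected to give about 4.8 ug/mL in this assay. The expected range for compound 4 runs from 2.5 ug/mL to 9 ug/mL.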

Compound 4, half-maximal inhibitory concentration: 4.21 ug/mL
Compound 4: the middle estimate sits 1.1-fold (0.06 log units) above what was measured; the measured number falls inside the stated range.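

In this assay, putting 3,4-difluorophenyl in place of 4-(trifluoromethyl)phenyl on the carbonyl carbon gives a 1.5-fold lower number from compound 2 to compound 4 (0.17 log units; within the scatter), and this step cannot be told apart from the one seen on the other core: the same change on two cores in this assay, a 1.3-fold lower number (0.11 log units; within the scatter) from compound 3 to compound 1 and a 1.5-fold lower number (0.17 log units; within the scatter) from compound 2 to compound 4, 1.1-fold (0.05 log units) apart, within the scatter of two such steps. The second change, hydrogen in place of trifluoromethyl on an aromatic carbon, gives a 1.1-fold lower number from compound 1 to compound 4 (0.02 log units; within the scatter), and it also matches its earlier counterpart: the same change on two cores in this assay, a 1.1-fold lower number (0.03 log units; within the scatter) from compound 2 to compound 3 and a 1.1-fold higher number (0.02 log units; within the scatter) from compound 4 to compound 1, 1.1-fold (0.05 log units) apart, within the scatter of two such steps. Across these four compounds, then, each change carries from one core to the other without a detectable difference, but all of these steps are small enough to be repeat-measurement noise, so this is agreement between near-zero steps and does not show that either change truly shifts the number or would behave alike on other cores.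

The groups on the aromatic rings shown here are all fluorine-bearing, so the effect of an amine or a carboxylic acid at those places remains open. Also open, as far as these compounds go, is whether any change on this core can produce a step beyond the scatter.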